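This account rests on a few compounds, and the source may have more. Where it says the series, first, only, none or still open, it means among the compounds named here.

Going by the values given here, in a functional assay on L1210 cells (Mus musculus) for inhibition, with a stated time of 96 h (a higher number here means a weaker inhibitor, a lower number a stronger inhibitor), compound 2 (`NCCCCCNCCCCN`) gives 180 nM, the lower of the two numbers so far, while compound 1 (`CCCNCCCCNCCCCN`) gives 600 nM. Compound 3 (`NCCCCCNCCCCCN`) differs from compound 2 by aminomethyl in place of amino on a saturated chain carbon, four bonds along the chain from an amine nitrogen. Among the compounds with values here, only one measured step bears on this change, a 3.3-fold lower number from compound 1 to compound 2 (0.52 log units; beyond the scatter). That step is modest and also brings in aminomethyl at such a place, but there it replaces propylamino, so it is only an indirect guide. Within the data shown here, no measured step replaces amino itself, and the direction stays open. A step within the scatter is therefore expected in this assay, with wide uncertainty. The estimated step is a 1.2-fold higher number from compound 2 to compound 3 (0.09 log units; within the scatter). For compound 3 the estimated value is 220 nM, with an expected range of 70 nM to 700 nM.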

Compound 3, half-maximal inhibitory concentration: 400 nM
The estimate for compound 3 lay 1.8-fold (0.26 log units) below the measured number, and the stated range covers the measured number.
By their numbers in this assay, from the lowest: compound 2; then compounds 3 and 1 (each within the scatter of the next).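

In this assay, going by these compounds alone, aminomethyl in place of amino on a saturated chain carbon, four bonds along the chain from an amine nitrogen, gives a 2.2-fold higher number from compound 2 to compound 3 (0.35 log units; beyond the scatter), the first direct reading of this change, and it shows that the direction is towards a weaker inhibitor. Read with a 3.3-fold lower number from compound 1 to compound 2 (0.52 log units; beyond the scatter), where aminomethyl replaces propylamino at such a place, this step leaves compound 2 with a lower number than either neighbour, each step beyond the scatter, so aminomethyl does not lower the number whichever group it replaces. No measurement on hand explains the difference between these two steps.

Going by these compounds, whether 2-aminoethyl or 3-aminopropyl at this place would continue the rise remains open. So does whether a hydroxyl or a carboxylic acid could stand in for the amino group at this place.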